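A few compounds are considered here, and "the series" means these few. Any claim that something is new, unique, unknown or untested is made for them only; others in the source may bear on it.

Two compounds of this series have a number in a functional assay for agonist activity at G protein-coupled receptor 88 (Homo sapiens), read by HTRF and cAMP accumulation; on this read-out higher numbers stand for an effect only at larger amounts of compound and lower numbers for an effect already at smaller amounts. Compound 1 `CCC(CC)C(N)CCN(C(=O)[C@@H]1C[C@H]1c1ccccc1)c1ccc(-c2ccccc2)cc1` gives 2 nM in this assay. Compound 2 `CC[C@H](C)[C@H](N)CN(C(=O)[C@@H]1C[C@H]1c1cccc(OC)c1)c1ccc(-c2ccccc2)cc1` gives 3000 nM in this assay, the higher of the two numbers, and its gap to compound 1 lies well beyond the scatter of repeated measurements. Compound 3 `CC[C@H](C)[C@H](N)CN(C(=O)[C@@H]1C[C@H]1c1cncnc1)c1ccc(-c2ccccc2)cc1` has not yet been measured. It differs from compound 2 in one place: pyrimidin-5-yl in place of 3-methoxyphenyl on a saturated ring carbon. Among the measured compounds shown here, no pair of measured compounds shows this change on its own, so nothing measured says how it acts in this assay. Given that compound 2 already stands at 3000 nM, compound 3 is expected to shift by about a 1.7-fold higher number from compound 2 to compound 3 (0.22 log units; within the scatter) toward a somewhat higher number, a step of modest size that may not exceed the scatter. Compound 3 is therefore estimated at 5000 nM in this assay, within a range from 1000 nM to 30000 nM.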

Compound 3, half-maximal effective concentration: 19000 nM
The estimate for compound 3 lay 3.8-fold (0.58 log units) below the measured number; the measured number falls inside the stated range.
By their numbers in this assay, from the lowest: compound 1; then compound 2; then compound 3.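

In this assay, among the compounds shown here, replacing 3-methoxyphenyl with pyrimidin-5-yl on the saturated ring carbon gives the first readable step at this position, a 6.3-fold higher number from compound 2 to compound 3 (0.80 log units; beyond the scatter). It shows that the number at this position depends on which six-membered aromatic ring is attached there, and that it can rise further even from the already high value of compound 2. No measurement at hand accounts for this step.

The compounds shown leave open whether the rise belongs to the loss of the methoxy group or to the entry of the ring nitrogens, and a plain phenyl or a pyridin-3-yl on the core of compound 2 would separate the two. Also open, on these data alone, is whether the same change acts alike on the core of compound 1.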